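Cinnamate glycolamide esters: dechlorination of the anilide ring

The compounds below may be only part of what the source reports. "The series", "measured", "known", "first", "only" and "open" are said of these compounds alone.

The series is read in a functional assay on HeLa cells (Homo sapiens) for cytotoxicity, read by MTT assay, with a stated time of 72 h; on this read-out higher numbers stand for weaker inhibition and lower numbers for stronger inhibition. Compound 1 `COc1ccc(/C=C/C(=O)OCC(=O)Nc2ccccc2)cc1OC` gives 193000 nM in this assay. Compound 2 `COCOc1cc(/C=C/C(=O)OCC(=O)NCc2ccco2)ccc1OCc1ccccc1` reaches only the limit of > 200000 nM in this assay. Compound 3 `CCOc1ccc(COc2c(OC)cc(/C=C/C(=O)OCC(=O)Nc3ccc(Cl)cc3)cc2OC)cc1` also stands at the limit of > 200000 nM in this assay, so no number is known for it; it shares this standing with one other value, as the limit of > 200000 nM in this assay, at which 2 of the 3 values shown sit, records. Compound 4 `CCOc1ccc(COc2c(OC)cc(/C=C/C(=O)OCC(=O)Nc3ccccc3)cc2OC)cc1` is not yet measured. It differs from compound 3 by hydrogen in place of chloro on an aromatic carbon. Among the measured compounds shown here, no step between measured compounds is available to size this change. In this assay the step from compound 3 to compound 4 is expected to be none beyond the scatter, a number no higher from compound 3 to compound 4 (the limit leaves the size open). Compound 4 is therefore expected to give 200000 nM in this assay, within 100000 nM to 400000 nM, and most likely again only a limit.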

Compound 4, half-maximal inhibitory concentration: > 200000 nM
Compound 4 ended at the assay's limit; the forecaster's own chance of this, stated with the estimate: 60%; the middle value sits exactly at the limit.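

Compound 3 and compound 4 both stand at a limit in this assay rather than at a number, so no step between them can be read: the limit of > 200000 nM in this assay, at which 3 of the 4 values shown sit.

The compounds shown leave open whether 4-chlorophenyl and phenyl differ at all on this read-out.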